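Replacing the phenyl carbamate of compound 1 with cyclohexyl

The compounds below may be only part of what the source reports. "The series", "measured", "known", "first", "only" and "open" are said of these compounds alone.

Of the compounds shown here, three sharing one core have been measured in a functional assay on MT4 cells (Homo sapiens) for inhibition; on this read-out higher numbers stand for weaker inhibition and lower numbers for stronger inhibition. Compound 1 `C/C(=C\COC(=O)Nc1ccccc1)C1=CC(=O)C(C)(C)O1` gives 103 ug/mL, the highest of the three numbers. Compound 2 `COc1ccc(/C=C/C=C(\C)C2=CC(=O)C(C)(C)O2)cc1` gives 5.7 ug/mL, and compound 3 `C/C(=C\C=C\c1ccccc1)C1=CC(=O)C(C)(C)O1` gives 6.5 ug/mL; both numbers lie well below that of compound 1, beyond the scatter. Among the measured compounds shown here, the only step between two measured compounds that differ in one place is a 1.1-fold higher number from compound 2 to compound 3 (0.06 log units; within the scatter), which concerns a methoxy on an aromatic carbon and does not touch the carbamate side of compound 1.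

Compound 4 `C/C(=C\COC(=O)NC1CCCCC1)C1=CC(=O)C(C)(C)O1` differs from compound 1 by cyclohexyl in place of phenyl on an amide-type nitrogen. For the measured compounds named here, no measured pair shows what exchanging an aromatic ring for a saturated one on this amide-type nitrogen does, so there is nothing to build a direction on. Compound 4 is therefore expected to give about 100 ug/mL, with a range from 40 ug/mL to 250 ug/mL. The expected step of a 1.0-fold lower number from compound 1 to compound 4 (0.01 log units; within the scatter) is thus no change beyond the scatter, and the range is set wide to reflect the lack of a comparable step.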

Compound 4, half-maximal inhibitory concentration: 2.4 ug/mL
The estimate for compound 4 lay 42-fold (1.62 log units) above the measured number; the whole stated range lies above it.
By their numbers in this assay, from the lowest: compound 4; then compounds 2 and 3 (each within the scatter of the next); then compound 1.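

In this assay, cyclohexyl in place of phenyl on the amide-type nitrogen gives a 43-fold lower number from compound 1 to compound 4 (1.63 log units; beyond the scatter), so the number depends strongly on which ring stands at this position. Among the compounds shown here, the two groups have the same heavy-atom count, and one ring is aromatic while the other is not; the only earlier step, concerning a methoxy on an aromatic carbon, stayed within the scatter and gave no sign of such sensitivity. Nothing at hand bears on why this step is so large.

The compounds shown leave open whether the lower number is particular to cyclohexyl or extends to other saturated groups on this nitrogen, such as cyclopentyl or a straight hexyl chain. They also leave open what a methoxy on the phenyl of compound 1 would do.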